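A few compounds are considered here, and "the series" means these few. Any claim that something is new, unique, unknown or untested is made for them only; others in the source may bear on it.

Series notes. The shared core of compound 2 `C/C=C/C(=O)Nc1ccc(Cn2nc(-c3ccc(Oc4ccccc4)cc3)cc2C(=O)O)cc1` carries a prop-1-en-1-yl group on the amide carbonyl, and in a functional assay on Rec1 cells (Homo sapiens) for inhibition, read by luminescence and CellTiter-Glo, with a stated time of 72 h (a lower number here means a stronger inhibitor, a higher number a weaker inhibitor), compound 2 gives 23600 nM. Compound 1 `C=CC(=O)Nc1ccc(Cn2nc(-c3ccc(Oc4ccccc4)cc3)cc2C(=O)O)cc1` differs from it by vinyl in place of prop-1-en-1-yl on a carbonyl carbon. In this assay compound 1 gives > 60000 nM, which is a limit of the assay and not a number. The step of an at least 2.5-fold higher number from compound 2 to compound 1 (0.40 log units; beyond the scatter) is therefore open at its upper end because the limit of > 60000 nM in this assay, at which 1 of the 3 values shown sits, caps what can be read for compound 1.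

Compound 3 `C/C=C/C(=O)Nc1cccc(Cn2nc(-c3ccc(Oc4ccccc4)cc3)cc2C(=O)OCC)c1` sits on a different core; the difference between the two cores is not broken down here. In this assay compound 3 gives 7800 nM, the lowest of the two numbers obtained, with compound 2 the nearest to it.

Compound 4 `C=CC(=O)Nc1cccc(Cn2nc(-c3ccc(Oc4ccccc4)cc3)cc2C(=O)OCC)c1` has not yet been measured in this assay. It differs from compound 3 by vinyl in place of prop-1-en-1-yl on a carbonyl carbon, the same change at the same place as that between compound 2 and compound 1. For compound 4 the step of a 3.2-fold higher number from compound 3 to compound 4 (0.51 log units; beyond the scatter) is expected. This expectation rests on an at least 2.5-fold higher number from compound 2 to compound 1 (0.40 log units; beyond the scatter), which ran toward a weaker inhibitor, and on the fact that the measured size of that step is only a floor. Compound 4 is accordingly estimated at 25000 nM in this assay, with a plausible range from 10000 nM to 60000 nM. Given where compound 3 starts, a reading that is itself a limit rather than a number would not be surprising for compound 4.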

Compound 4, half-maximal inhibitory concentration: 3300 nM
For compound 4 the middle estimate is 7.6-fold (0.88 log units) above the measured one; the measured number lies below the stated range.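

Working conclusion on transfer: in this assay, vinyl in place of prop-1-en-1-yl on the carbonyl carbon gives a 2.4-fold lower number from compound 3 to compound 4 (0.37 log units; beyond the scatter), so the step read on one core did not carry to the other, and the direction of the change differs between the two cores: the same change on two cores in this assay, an at least 2.5-fold higher number (0.40 log units; beyond the scatter) from compound 2 to compound 1 and a 2.4-fold lower number (0.37 log units; beyond the scatter) from compound 3 to compound 4, at least 6.0-fold (0.77 log units) apart, beyond the scatter of two such steps

Compound 1 gives > 60000 nM, which is a limit of the assay and not a number, so the size of the gap between the two steps is known only as a floor. The comparison rests on one pair per core and the difference between the cores is not broken down, so it shows that this change cannot be assumed to transfer within the series, but not which feature of the cores goes with the reversal, nor how the change would behave on any third core.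

Open, on these data alone, is whether the ethyl ester or the remaining difference between the cores goes with the change of direction, which would take compounds differing from these in one place only. Also open, as far as these compounds go, is how a longer chain, or a chain bearing an amine, would read on the same carbonyl carbon on each of the two cores.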